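Dimethylamino on the thiadiazole of a bis(trifluoromethyl)phenyl piperazine

The source may report more compounds than this note shows. Statements on the series, on what has been measured and on what is new or still open speak of the compounds shown alone.

Of the compounds shown here, three have been tested in a functional assay (aorta) for inhibition, with Rattus norvegicus as the target, with a stated time of 8 days; a higher number here means a weaker inhibitor, a lower number a stronger inhibitor. Compound 1 `FC(F)(F)c1cc(N2CCN(c3ccc(-c4ncns4)nn3)CC2)cc(C(F)(F)F)c1` gives a value in this assay that is a limit of the assay and not a number, < 1 nM. Compound 2 `FC(F)(F)c1cccc(N2CCN(C3CCN(c4ccc(-c5ncns5)nn4)CC3)CC2)c1` gives 0.3 nM in this assay. Compound 3 `CN(C)c1nsc(-c2ccc(N3CCC(N4CCN(c5cccc(C(F)(F)F)c5)CC4)CC3)nn2)n1` likewise gives only a limit, < 1 nM. Compound 3 differs from compound 2 by dimethylamino in place of hydrogen on an aromatic carbon, and the size of that step, a step that the limit leaves unreadable from compound 2 to compound 3, cannot be read, due to the limit of < 1 nM in this assay, at which 2 of the 3 values shown sit. The difference between the cores of compound 1 and compound 2 is not broken down here.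

Compound 4 `CN(C)c1nsc(-c2ccc(N3CCN(c4cc(C(F)(F)F)cc(C(F)(F)F)c4)CC3)nn2)n1` is not yet measured. It differs from compound 1 by dimethylamino in place of hydrogen on an aromatic carbon, the same kind of change as from compound 2 to compound 3. Since compound 1 already sits at the limit, the step from compound 1 to compound 4 in this assay is expected to be small, a step that the limit leaves unreadable from compound 1 to compound 4. Compound 4 is estimated at 0.4 nM, with a range from 0.1 nM to 1.5 nM.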

Compound 4, half-maximal inhibitory concentration: 0.1 nM
Compound 4: middle estimate off by 4.0-fold (0.60 log units), on the high side; low and high end bracket the measured number.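

The step from compound 1 to compound 4 cannot be read, because one of its two values is only a limit of the assay and not a number: the limit of < 1 nM in this assay, at which 2 of the 4 values shown sit.

The compounds shown leave open how large the effect of dimethylamino in place of hydrogen on an aromatic carbon is in this assay, on either core.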